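A few compounds are considered here, and "the series" means these few. Any claim that something is new, unique, unknown or untested is made for them only; others in the source may bear on it.

In an ADME assay on Vero cells (Chlorocebus sabaeus) for cytotoxicity, read by resazurin assay, with a stated time of 72 h (on this read-out lower numbers stand for stronger inhibition and higher numbers for weaker inhibition), compound 1 `O=C(CCN1CCN(c2ccc(F)cc2)CC1)c1ccccc1` gives 13400 nM and compound 2 `O=C(CCN1CCN(c2ccc(C(F)(F)F)cc2)CC1)c1ccccc1` gives 15700 nM, so compound 2 stands level with compound 1 within the scatter. Compound 3 `COc1ccc(C(=O)CCN2CCN(c3ccc(C(F)(F)F)cc3)CC2)cc1` differs from compound 2 by one change: methoxy in place of hydrogen on an aromatic carbon. Going by the values given here, the only measured step, a 1.2-fold higher number from compound 1 to compound 2 (0.07 log units; within the scatter), lies within the scatter, but it concerns a different group, so no measurement tests methoxy directly. No step beyond the scatter is therefore expected, and the estimated step is a 1.0-fold lower number from compound 2 to compound 3 (0.02 log units; within the scatter). The estimate for compound 3 is 15000 nM, with an expected range of 7000 nM to 30000 nM.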

Compound 3, half-maximal inhibitory concentration: 135000 nM
Estimate against measurement, compound 3: 9.0-fold (0.95 log units) below; measured number outside the range, above it.
By their numbers in this assay, from the lowest: compounds 1 and 2 (each within the scatter of the next); then compound 3.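

Changing phenyl to 4-methoxyphenyl gives an 8.6-fold higher number from compound 2 to compound 3 (0.93 log units; beyond the scatter) in this assay, which means weaker inhibition of the cells. This position, para to a large group, therefore responds strongly to a small added group, something the earlier change at the other end of the molecule did not reveal. Nothing measured here accounts for this step.

Open, from the compounds shown here alone, is whether a hydroxyl or an amine in the same place would move the number as methoxy does. Also open, going by these compounds, is whether methoxy would have the same effect on compound 1.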